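The source may report more compounds than this note shows. Statements on the series, on what has been measured and on what is new or still open speak of the compounds shown alone.

Measured compounds:
compound 1 `Cc1cnc(Nc2ccc(C(=O)Nc3c(C)cccc3C)cc2)nc1-c1ccc(OC(F)(F)F)cc1` — 1.3 nM
compound 2 `Cc1cnc(Nc2ccc(C(=O)Nc3c(C)cccc3C)cc2)nc1-c1ccccc1` — 1.3 nM

In an assay on NIH3T3 cells for inhibition of Sonic hedgehog protein (Mus musculus), read by a luciferase reporter, with a stated time of 48 h (a lower number here means a stronger inhibitor, a higher number a weaker inhibitor), compound 1 gives 1.3 nM and compound 2 gives 1.3 nM. Going by the values given here, the only measured step, no change at the digits printed from compound 1 to compound 2 (within the scatter) (hydrogen in place of trifluoromethoxy on an aromatic carbon), leaves the read-out where it was. Compound 2 therefore stands level with compound 1 on the numbers shown, and both sit at the low end of what this assay reports.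

Compound 3 `Cc1cnc(Nc2ccc(C(=O)Nc3c(C)cccc3C)cc2)nc1-c1ccncc1` differs from compound 2 by pyridin-4-yl in place of phenyl on an aromatic carbon. Among the compounds with values here, no measured step touches this ring, so nothing in the data speaks directly to the change. Within the data shown here, the one step that exists, no change at the digits printed from compound 1 to compound 2 (within the scatter), shows that a substituent change on this same ring did not move the result beyond the scatter. On that basis compound 3 is expected to stay close to compound 2, with a step of a 1.5-fold higher number from compound 2 to compound 3 (0.19 log units; within the scatter) estimated in this assay. Compound 3 is therefore estimated at 2 nM, with a range from 0.5 nM to 8 nM.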

Compound 3, half-maximal inhibitory concentration: 0.54 nM
Estimate against measurement, compound 3: 3.7-fold (0.57 log units) above; the range from low to high includes it.
By their numbers in this assay, from the lowest: compound 3; then compounds 1 and 2 (each within the scatter of the next).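

Until now, this position had looked indifferent in this assay, since removing the trifluoromethoxy group gave no change at the digits printed from compound 1 to compound 2 (within the scatter). The new result shows that the aromatic group on this carbon, which is next to the ring nitrogen and ortho to a methyl group, can affect the read-out: pyridin-4-yl in place of phenyl gives a 2.4-fold lower number from compound 2 to compound 3 (0.38 log units; beyond the scatter), and pyridin-4-yl in place of 4-(trifluoromethoxy)phenyl gives a 2.4-fold lower number from compound 1 to compound 3 (0.38 log units; beyond the scatter). Both steps are modest, but they show that a change within the ring itself, with a hetero atom entering in place of carbon, registers here where the loss of the trifluoromethoxy group did not, and nothing available accounts for this difference.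

The compounds shown leave open how other heteroaromatic rings, such as pyrazine or thiazole, would read at this carbon. They also leave open whether the lower number would survive an amine, a carboxylic acid or a longer chain attached to the pyridin-4-yl ring.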